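A few compounds are considered here, and "the series" means these few. Any claim that something is new, unique, unknown or untested is made for them only; others in the source may bear on it.

The three measured compounds share one core and differ only in the group on the sulfonyl sulfur of the sulfonamide: compound 1 `CCCS(=O)(=O)Nc1cccc2c1CCCC2c1c[nH]cn1` carries propyl, compound 2 `CC(C)S(=O)(=O)Nc1cccc2c1CCCC2c1c[nH]cn1` isopropyl and compound 3 `CN(C)S(=O)(=O)Nc1cccc2c1CCCC2c1c[nH]cn1` dimethylamino. In an assay on isolated protein (Cricetulus griseus) for binding affinity to Alpha-1B adrenergic receptor (Mesocricetus auratus), read by radioligand binding (on this read-out lower numbers stand for stronger inhibition and higher numbers for weaker inhibition), compound 1 gives only a limit of < 10000 nM. Compound 2 likewise gives a limit of < 10000 nM. Compound 3 also stands at a limit of < 10000 nM, so its position among the numbers shown is not fixed. The steps a step that the two limits leave unreadable from compound 1 to compound 2, a step that the two limits leave unreadable from compound 1 to compound 3 and a step that the two limits leave unreadable from compound 2 to compound 3 cannot be read, because all three values sit at the same limit (the limit of < 10000 nM in this assay, at which 3 of the 3 values shown sit). Compound 4 `Nc1cccc2c1CCCC2c1c[nH]cn1` goes one step further out, with hydrogen in place of dimethylsulfamoyl on a nitrogen on an aromatic ring, so that the whole sulfonamide is lost and a bare amino remains. Going by the values given here, no measured step bears on this change, and the unreadable steps among compounds 1 to 3 give no sense of direction. The step from compound 3 to compound 4 is therefore only guessed and is expected to be a step that the limit leaves unreadable from compound 3 to compound 4. For compound 4 the expected value in this assay is 2000 nM, within 100 nM to 30000 nM.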

Compound 4, inhibition constant: 525 nM
The estimate for compound 4 lay 3.8-fold (0.58 log units) above the measured number; the measured number falls inside the stated range.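

No new step can be read from compound 1, compound 2 or compound 3 to compound 4, because those three compounds stand only at a limit: the limit of < 10000 nM in this assay, at which 3 of the 4 values shown sit. In this assay the compounds shown leave open how far compound 1, compound 2 and compound 3 lie from compound 4, and how they rank among themselves.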